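Methoxy for fluoro on the other aryl ring

A few compounds are considered here, and "the series" means these few. Any claim that something is new, unique, unknown or untested is made for them only; others in the source may bear on it.

Compound 1 `O=C(/C=C\Nc1ccc(F)cc1)c1cn(-c2ccccc2)nc1-c1ccc(F)cc1` is the weaker of the two compounds measured in a functional assay on HT-29 cells (Homo sapiens) for antiproliferative activity, read by MTT assay, with a stated time of 48 h (on this read-out higher numbers stand for weaker inhibition and lower numbers for stronger inhibition), where compound 1 gives 6500 nM. Its neighbour compound 2 `COc1ccc(N/C=C\C(=O)c2cn(-c3ccccc3)nc2-c2ccc(F)cc2)cc1` gives 3200 nM, a step of a 2.0-fold lower number from compound 1 to compound 2 (0.31 log units; beyond the scatter) brought by methoxy in place of fluoro on an aromatic carbon. Compound 3 `COc1ccc(-c2nn(-c3ccccc3)cc2C(=O)/C=C\Nc2ccc(F)cc2)cc1` carries the same exchange, (methoxy in place of fluoro on an aromatic carbon), but on the other ring of the shared core. Among the measured compounds shown here, only that one step on a different ring bears on it, so a modest gain or none is expected, a 1.4-fold lower number from compound 1 to compound 3 (0.16 log units; within the scatter). Compound 3 is therefore estimated at 4500 nM, within 2000 nM to 10000 nM.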

Compound 3, half-maximal inhibitory concentration: 7650 nM
Compound 3: the middle estimate sits 1.7-fold (0.23 log units) below what was measured, and the stated range covers the measured number.
By their numbers in this assay, from the lowest: compound 2; then compounds 1 and 3 (each within the scatter of the next).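

Changing 4-fluorophenyl to 4-methoxyphenyl at this position of the shared core gives a 1.2-fold higher number from compound 1 to compound 3 (0.07 log units; within the scatter) in this assay, so here methoxy and fluoro cannot be told apart. Among the compounds shown here, of the two placements of this exchange, only the one on the other aryl ring, a 2.0-fold lower number from compound 1 to compound 2 (0.31 log units; beyond the scatter), lies beyond the scatter, so the step seen there does not carry over to this ring. Nothing available explains this difference.

As far as these compounds go, it remains open whether a chloro or an amino group at this position would separate from fluoro, and whether methoxy on both aryl rings together would shift the number further.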